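Swapping the fluoromethylphenyl arm for a bromophenyl arm

The compounds below may be only part of what the source reports. "The series", "measured", "known", "first", "only" and "open" are said of these compounds alone.

Three analogues sharing one core have been examined in a functional assay on HeLa cells (Homo sapiens) for cytotoxicity, read by CCK-8 assay, with a stated time of 72 h; on this read-out higher numbers stand for weaker inhibition and lower numbers for stronger inhibition. Compound 1 `COc1ccccc1/C=c1/[nH]c(=O)/c(=C\c2ccccc2OC)[nH]c1=O` is recorded as "not active" (no number reported) in this assay. Compound 2 `C=CCn1c(=O)/c(=C\c2cc(F)ccc2C)[nH]c(=O)/c1=C\c1ccccc1OC` gives 2900 nM in this assay, the highest number among the two compounds that returned a number. Compound 3 `COc1ccccc1/C=c1\c(=O)[nH]/c(=C/c2ccccc2Cl)c(=O)n1C` gives 300 nM in this assay, a lower number than compound 2, though no direct comparison between the pair is available. Compound 4 `C=CCn1c(=O)/c(=C\c2cccc(Br)c2)[nH]c(=O)/c1=C\c1ccccc1OC` has not yet been measured. It differs from compound 2 by 3-bromophenyl in place of 5-fluoro-2-methylphenyl on a double-bonded chain carbon bound to an aromatic carbon. Going by the values given here, with no measured pair isolating this change, the step from compound 2 to compound 4 is expected to be a 1.9-fold lower number from compound 2 to compound 4 (0.29 log units; within the scatter), a modest move toward a lower number that may not exceed the scatter. Compound 4 is therefore estimated at 1500 nM in this assay, within 400 nM to 6000 nM.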

Compound 4, half-maximal inhibitory concentration: 5400 nM
Compound 4: the middle estimate sits 3.6-fold (0.56 log units) below what was measured; measured number inside the range.
By their numbers in this assay, from the lowest: compound 3; then compounds 2 and 4 (each within the scatter of the next).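

In this assay, putting 3-bromophenyl in place of 5-fluoro-2-methylphenyl on a double-bonded chain carbon bound to an aromatic carbon gives a 1.9-fold higher number from compound 2 to compound 4 (0.27 log units; within the scatter), so the two compounds cannot be told apart. This one-place comparison shows that this position accepts an arm with a different halogen, at a different place on the ring and without the methyl, with no change beyond the scatter. No measured evidence bears on this result.

On these data alone, whether an amine or a carboxylic acid on this arm would shift the number beyond the scatter remains open. Whether a single fluorine or methyl alone would do so is also unresolved.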